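Ester variation on the shared core: cytotoxicity in HeLa cells

The compounds below may be only part of what the source reports. "The series", "measured", "known", "first", "only" and "open" are said of these compounds alone.

Compound 1 `C=C1C(=O)O[C@@H]2CC(C)=C([C@@H](C)CCCOC(C)=O)[C@@H](OC(=O)CCl)[C@H]12` carries a chloromethyl group on the carbonyl carbon of its ester. Among the compounds with values here, in a functional assay on HeLa cells (Homo sapiens) for cytotoxicity, read by sulforhodamine B assay, with a stated time of 72 h (on this read-out lower numbers stand for stronger inhibition and higher numbers for weaker inhibition), compound 1 gives 28500 nM, the highest of the three numbers measured so far. Compound 2 `C=C1C(=O)O[C@@H]2CC(C)=C([C@@H](C)CCCOC(C)=O)[C@@H](OC(=O)CN3CCCC3)[C@H]12` gives 12700 nM, and compound 3 `C=C1C(=O)O[C@@H]2CC(C)=C([C@@H](C)CCCOC(C)=O)[C@@H](OC(=O)c3ccccc3)[C@H]12` gives 5190 nM. The steps are a 2.2-fold lower number from compound 1 to compound 2 (0.35 log units; beyond the scatter) and a 5.5-fold lower number from compound 1 to compound 3 (0.74 log units; beyond the scatter), with a 2.4-fold lower number from compound 2 to compound 3 (0.39 log units; beyond the scatter) between the two replacements.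

Compound 4 `C=C1C(=O)O[C@@H]2CC(C)=C([C@@H](C)CCCOC(C)=O)[C@@H](OC(=O)c3cccc(F)c3)[C@H]12` differs from compound 1 at the same place: 3-fluorophenyl in place of chloromethyl on a carbonyl carbon. Within the data shown here, the step that bears most directly is the one to compound 3, where a phenyl enters at this carbonyl carbon; compound 4 differs from compound 3 only by the fluorine on that ring, for which no step is measured. A step of about the size seen from compound 1 to compound 3 is therefore expected, in the same direction, as a 5.7-fold lower number from compound 1 to compound 4 (0.76 log units; beyond the scatter). For compound 4 the estimate in this assay is 5000 nM, with a range from 2000 nM to 13000 nM.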

Compound 4, half-maximal inhibitory concentration: 11800 nM
Beside the measured number, compound 4's estimate is 2.4-fold (0.37 log units) below it; the measured number falls inside the stated range.
By their numbers in this assay, from the lowest: compound 3; then compounds 4 and 2 (each within the scatter of the next); then compound 1.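

In this assay the ring at this carbonyl carbon proves sensitive to substitution: fluoro in place of hydrogen on an aromatic carbon gives a 2.3-fold higher number from compound 3 to compound 4 (0.36 log units; beyond the scatter) and so takes back part of the gain seen with the plain phenyl. The 3-fluorophenyl ester still stands apart from the chloromethyl ester, with a 2.4-fold lower number from compound 1 to compound 4 (0.38 log units; beyond the scatter) as the step, while a 1.1-fold lower number from compound 2 to compound 4 (0.03 log units; within the scatter) leaves it level with the (pyrrolidin-1-yl)methyl ester. An aromatic ring at this place therefore does not by itself give a lower number than the pyrrolidine group: compound 3 does and compound 4 does not.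

As far as these compounds go, whether the fluorine itself or its place on the ring sets this step stays open, as does the outcome with a methoxy group or chlorine on the ring, or with a longer chain leading to the pyrrolidine. No measurement available here accounts for the fluorine step.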